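This account rests on a few compounds, and the source may have more. Where it says the series, first, only, none or still open, it means among the compounds named here.

Compound 1, with the structure `C=C1CCC[C@H]2[C@](C)(CC[C@]3(C)CC[C@@H]([C@@H](C)C(=O)O)OO3)[C@@H](C)CC[C@]12C`, is the starting point of this comparison. In a functional assay on U-251 cells (Homo sapiens) for inhibition (on this read-out lower numbers stand for stronger inhibition of growth and higher numbers for weaker inhibition of growth), compound 1 gives 930 nM, the lowest of the two numbers that have been obtained here. Its nearest neighbour among the measured compounds is compound 3, whose structure is `C=C1CCCC(C)(C)C1CC[C@@]1(C)CC[C@H]([C@@H](C)C(=O)O)OO1`; in this assay compound 3 gives 4330 nM, a higher number than that of compound 1 by a gap that lies beyond the usual scatter. Compound 2, with the structure `CC1=C(CC/C(C)=C/CC[C@@]2(C)CC[C@@H]([C@H](C)C(=O)O)OO2)C(C)(C)CCC1`, reaches only a limit of this assay rather than a number: in this assay compound 2 gives > 100000 nM, and the limit of > 100000 nM in this assay, at which 1 of the 3 values shown sits, records that this is where one of the three values sits.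

The step under consideration leads from compound 1 to compound 4, whose structure is `C=C1CCC[C@H]2[C@](C)(CC[C@]3(C)CC[C@H]([C@@H](C)C(=O)O)OO3)[C@@H](C)CC[C@]12C`. The change is small on paper: the two compounds have the same atoms and bonds and differ only in configuration as drawn: 1 of 7 stereo elements differ; a stereocentre at a saturated ring carbon is drawn S in compound 1 and R in compound 4. Among the compounds with values here, no measured pair here differs in only one place, so there is no directly comparable step to lean on. A change of configuration at a ring carbon can alter growth inhibition noticeably, yet with the rest of the molecule untouched a modest weakening is the most cautious expectation. The step from compound 1 to compound 4 is estimated at a 2.2-fold higher number from compound 1 to compound 4 (0.33 log units; beyond the scatter). Compound 4 is therefore expected to give about 2000 nM in this assay, with a likely range from 500 nM to 8000 nM.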

Compound 4, concentration for 50% growth inhibition: 1730 nM
The estimate for compound 4 lay 1.2-fold (0.06 log units) above the measured number, within the range that was stated.
By their numbers in this assay, from the lowest: compounds 1 and 4 (each within the scatter of the next); then compound 3. At a limit, above all of these: compound 2.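

Turning the stereocentre at a saturated ring carbon from S to R gives, in this assay, a 1.9-fold higher number from compound 1 to compound 4 (0.27 log units; within the scatter). This is the only pair shown that differs in a single place, so it offers the one direct reading of a change in this set: at this carbon, the drawn configuration has no effect on growth inhibition that can be told apart from the usual scatter of repeated measurements. The reading can be tied to this one stereocentre because no atom or bond changes between the two structures, and the other stereo elements stay as they were: the fact that compounds 1 and 4 differ only in the configuration as drawn

The pair speaks for one stereocentre on one core, so the compounds shown leave open whether the other stereo elements of that core can be inverted as freely, or whether compound 2 and compound 3 would respond in the same way to this inversion. They also leave open whether either configuration would still serve if the carboxylic acid gave way to a methyl ester or an amide, which would show whether the result at this carbon depends on the group attached to it.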